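This account rests on a few compounds, and the source may have more. Where it says the series, first, only, none or still open, it means among the compounds named here.

Compound 1 `CNC(=O)c1cc(Oc2ccc3oc(Nc4ccccc4F)nc3c2)ccn1` and compound 2 `CNC(=O)c1cc(Oc2ccc3oc(Nc4ccccc4Cl)nc3c2)ccn1` share one core and differ only in a halogen on an aromatic carbon, chloro standing in for fluoro. In an ADME assay on Caco-2 cells (Homo sapiens) for permeability, in the apical to basolateral direction (on this read-out higher numbers stand for higher permeability and lower numbers for lower permeability), compound 1 gives 10 10^-6 cm/s, and in this assay compound 2 gives 10 10^-6 cm/s. The step of no change at the digits printed from compound 1 to compound 2 (within the scatter) lies within the scatter, so compound 2 stands level with compound 1 and is its nearest neighbour on this read-out. Compound 3 `CCc1ccccc1Nc1nc2cc(Oc3ccnc(C(=O)NC)c3)ccc2o1` is not yet measured. It differs from compound 2 by ethyl in place of chloro on an aromatic carbon; the new group sits on an aromatic carbon of a six-membered aromatic ring of carbon only, ortho to a large group. Within the data shown here, the only measured step that bears on this change is the halogen swap, no change at the digits printed from compound 1 to compound 2 (within the scatter), which was flat. Compound 3 is therefore expected to show no shift beyond the scatter, a step of no change at the digits printed from compound 2 to compound 3 (within the scatter). The estimate for compound 3 in this assay is 10 10^-6 cm/s, with a range from 6 10^-6 cm/s to 17 10^-6 cm/s.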

Compound 3, apparent permeability: 10 10^-6 cm/s
Estimate against measurement, compound 3: no gap at the digits printed; low and high end bracket the measured number.
By their numbers in this assay, from the lowest: compounds 1, 2 and 3 (each within the scatter of the next).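

In this assay the place on the aromatic carbon, ortho to a large group, now takes a carbon substituent as well as halogens without any shift: ethyl in place of chloro gives no change at the digits printed from compound 2 to compound 3 (within the scatter), and ethyl in place of fluoro gives no change at the digits printed from compound 1 to compound 3 (within the scatter). The flat result is therefore no longer confined to an exchange of one halogen for another, and it holds across all three compounds, including the change from 2-chlorophenyl to 2-ethylphenyl. Nothing available explains why the read-out stays level at this place.

Chloro and ethyl both carry no net charge and no hydrogen-bond donors or acceptors, so it remains open whether an amine, a carboxylic acid or a longer alkyl chain would stay level here. The compounds shown also leave open whether the same changes would stay flat elsewhere on this ring.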